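Swapping a carbamate cap for an oxadiazolylmethyl arm

The source may hold more compounds than are shown below. What is called first, only, known or untested is meant among the compounds shown, and "the series" means these compounds.

In a functional assay on isolated protein for agonist activity at Glucose-dependent insulinotropic receptor (Homo sapiens), read by HTRF and cAMP accumulation (on this read-out lower numbers stand for an effect already at smaller amounts and higher numbers for an effect only at larger amounts of compound), compound 3 `CS(=O)(=O)c1cnc(O[C@H]2CC[C@H](OC3CCN(C(=O)OC4CCOC4)CC3)CC2)cn1` gives 427 nM, the highest of the three numbers recorded. Compound 2 `Cc1nc(O[C@H]2CC[C@H](OC3CCN(C(=O)OC(C)(C)C)CC3)CC2)ccc1C(=O)N(C)C` gives 262 nM, which lies within the scatter of compound 3, so the two cannot be ranked. Compound 1 `CC(C)(C)OC(=O)N1CCC(O[C@H]2CC[C@H](Oc3ccc(C#N)cc3)CC2)CC1` gives 8.6 nM, a gap beyond the scatter that leaves compound 1 clearly ahead of compound 3. Compound 4 `CC(F)Cc1nc(CN2CCC(O[C@H]3CC[C@H](Oc4cnc(S(C)(=O)=O)cn4)CC3)CC2)no1` is not yet measured; it differs from compound 3 by (5-(2-fluoropropyl)-1,2,4-oxadiazol-3-yl)methyl in place of ((oxolan-3-yl)oxy)carbonyl on an amine nitrogen in a ring. For the measured compounds named here, no measured pair follows this change, so the direction rests on judgment alone. The number for compound 4 is expected to move modestly downward, by a 2.1-fold lower number from compound 3 to compound 4 (0.33 log units; beyond the scatter), although a step no larger than the scatter would not surprise. Compound 4 is therefore estimated at 200 nM, within a range from 40 nM to 1500 nM.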

Compound 4, half-maximal effective concentration: 30.3 nM
Beside the measured number, compound 4's estimate is 6.6-fold (0.82 log units) above it, outside the stated range (below it).
By their numbers in this assay, from the lowest: compound 1; then compound 4; then compounds 2 and 3 (each within the scatter of the next).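

In this assay there is a 14-fold lower number from compound 3 to compound 4 (1.15 log units; beyond the scatter) when (5-(2-fluoropropyl)-1,2,4-oxadiazol-3-yl)methyl replaces ((oxolan-3-yl)oxy)carbonyl, so the group on this amine nitrogen can matter a great deal. The earlier compounds shown here all had a carbonyl attached there, and compound 4 shows that activity in this range does not depend on one. Nothing available explains the size of this step. The compounds shown do not separate the contribution of the oxadiazole ring from that of the fluorine, so a plain propyl chain on the same ring remains an open comparison.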